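The source may hold more compounds than are shown below. What is called first, only, known or untested is meant among the compounds shown, and "the series" means these compounds.

Working notes on the series.

Compound 1 `COc1ccc(-c2cc(/C=C/C(=O)c3ccc(N)cc3)[nH]n2)cc1` was run in a functional assay on SK-MEL-5 cells (Homo sapiens) for cytotoxicity, read by sulforhodamine B assay, with a stated time of 48 h, tested at 0.01 uM (on this read-out lower numbers stand for a stronger effect and higher numbers for a weaker effect at the one concentration tested), where compound 1 gives 97%. Compound 3 `COc1ccc(-c2cc(/C=C/C(=O)c3ccc(N)cc3)[nH]n2)cc1OC` carries methoxy in place of hydrogen on an aromatic carbon; in this assay compound 3 gives 99%, so the step of a number 2 percentage points higher from compound 1 to compound 3 (within the scatter). Compound 2 `COc1ccc(C(=O)/C=C/c2cc(-c3cc(OC)c(OC)c(OC)c3)n[nH]2)cc1OC` rests on a different core; the difference between the two cores is not broken down here. In this assay compound 2 gives 97%, which sits level with compound 1 within the scatter, and its distance from compound 3 is likewise within the scatter. Compound 4 `COc1cc(C(=O)/C=C/c2cc(-c3cc(OC)c(OC)c(OC)c3)n[nH]2)cc(OC)c1OC` has not yet been measured. Within the data shown here, it differs from compound 2 by methoxy in place of hydrogen on an aromatic carbon; this is the same kind of change as the one from compound 1 to compound 3, with the surroundings differing in that the entering group of compound 4 is also meta to a methoxy group. Because the measured step of a number 2 percentage points higher from compound 1 to compound 3 (within the scatter) stayed within the scatter, a step of similar size is expected here, a number 1 percentage points higher from compound 2 to compound 4 (within the scatter). Compound 4 is accordingly estimated at 98%, with an expected range from 92% to 102%.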

Compound 4, a percentage reported as activity, at one concentration (the size of the read-out at that concentration, not a potency): 96%
The estimate for compound 4 lay 2 percentage points above the measured number; the range from low to high includes it.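

In this assay, methoxy in place of hydrogen on an aromatic carbon gives a number 1 percentage points lower from compound 2 to compound 4 (within the scatter), here ortho to a methoxy group and meta to a second one. Set beside the earlier case, the steps on the two cores do not differ beyond what repeated measurement would allow: the same change on two cores in this assay, a number 2 percentage points higher (within the scatter) from compound 1 to compound 3 and a number 1 percentage points lower (within the scatter) from compound 2 to compound 4, 3 percentage points apart, within the scatter of two such steps. This shows that the change leaves no readable step on either core at the one concentration tested, so carrying it from one core to the other is supported only in that narrow sense; it does not show that the change is without effect at other concentrations, or that it would behave alike on any further core.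

The compounds shown leave open how a hydroxyl group, a fluorine atom or a longer alkoxy chain would read in place of this methoxy. Also open, from the compounds shown here alone, is whether a step beyond the scatter could appear on either core in a concentration series.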